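This account rests on a few compounds, and the source may have more. Where it says the series, first, only, none or still open, it means among the compounds named here.

In a physicochemical assay for solubility, measured as kinetic solubility (on this read-out higher numbers stand for higher solubility and lower numbers for lower solubility), the measured compounds stand as follows.

- compound 1 `CNC(=O)c1cc(C(=O)N[C@H]2CC[C@H](O)CC2)c([C@@H](C)c2cccc(F)c2)o1` gives >= 63 ug/mL, a limit and not a number
- compound 2 `CNC(=O)c1cc(C(=O)NC2CC2)n(Cc2ccccc2)n1` gives >= 155 ug/mL, a limit and not a number
- compound 3 `CNC(=O)c1cc(C(=O)N[C@H]2CC[C@H](O)CC2)n([C@@H](C)c2cccc(C(F)(F)F)c2)n1` gives 7 ug/mL, a number

Compound 2 is known only as the limit of >= 155 ug/mL in this assay, at which 1 of the 3 values shown sits, so no exact value is available for it. Compound 4 `CNC(=O)c1cc(C(=O)NC2CC2)n([C@@H](C)c2ccccc2)n1` has not been measured, and its structure differs from that of compound 2 by methyl in place of hydrogen on a saturated chain carbon bound to an aromatic carbon and an aromatic nitrogen.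

Among the measured compounds shown here, no measured step isolates this change. Compound 3 also carries a methyl on a saturated chain carbon bound to an aromatic carbon and an aromatic nitrogen, and it reads 7 ug/mL. However, compound 3 differs from compound 2 in other places as well, so the two values give no step for the methyl alone. Compound 1 carries a methyl on a saturated chain carbon too and stands at >= 63 ug/mL, which is again a limit.

A modest fall in this assay is therefore expected, though with low confidence, and the estimated change is an at least 1.2-fold lower number from compound 2 to compound 4 (0.11 log units; that floor lies within the scatter). This step is measured from a limit, and the reading may itself return as a limit. The expected value for compound 4 is 120 ug/mL, with an estimated range of 40 ug/mL to 200 ug/mL.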

Compound 4, solubility: >= 165 ug/mL
Compound 4: no number, only a limit; the forecaster's own chance of this, stated with the estimate: 50%; at least 1.3-fold (0.13 log units) between middle value and limit.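

In this assay compound 2 gives >= 155 ug/mL, a limit and not a number. Compound 4 gives >= 165 ug/mL, also a limit, so no step can be read between these two compounds for methyl in place of hydrogen. The compounds shown leave open whether this methyl changes the reading in this assay at all, and in which direction.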